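This account rests on a few compounds, and the source may have more. Where it says the series, first, only, none or still open, it means among the compounds named here.

In a functional assay on A549 cells (Homo sapiens) for antiproliferative activity, read by MTT assay, with a stated time of 72 h (on this read-out lower numbers stand for stronger inhibition and higher numbers for weaker inhibition), compound 1 `C#Cc1cccc(Nc2ncnc3cc(OC)c(OCCCN4CCNCCNCCNCC4)cc23)c1` gives 28600 nM, the highest of the two numbers shown. Compound 2 `COc1cc2ncnc(Nc3ccc(F)c(Br)c3)c2cc1OCCCN1CCNCCNCCNCC1` gives 11800 nM, reached by a 2.4-fold lower number from compound 1 to compound 2 (0.38 log units; beyond the scatter). Compound 3 `COc1cccc(Nc2ncnc3cc(OC)c(OCCCN4CCNCCNCCNCC4)cc23)c1` is reported only as an assay limit, > 50000 nM. Compound 4 `COc1cc2ncnc(Nc3cccc(I)c3)c2cc1OCCCN1CCNCCNCCNCC1` differs from compound 1 in one place: iodo in place of ethynyl on an aromatic carbon. Within the data shown here, the steps that bear on this are the halogen-bearing ring of a 2.4-fold lower number from compound 1 to compound 2 (0.38 log units; beyond the scatter), which lowered the number modestly, and the methoxy replacement of an at least 1.7-fold higher number from compound 1 to compound 3 (0.24 log units; that floor lies within the scatter), which raised it to the limit (the limit of > 50000 nM in this assay, at which 1 of the 3 values shown sits). An iodo group resembles the former more than the latter, so a modest lowering, or none beyond the scatter, is expected from compound 1 to compound 4, a 1.6-fold lower number from compound 1 to compound 4 (0.20 log units; within the scatter). Compound 4 is therefore estimated at 18000 nM, between 7000 nM and 45000 nM.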

Compound 4, half-maximal inhibitory concentration: 14500 nM
The estimate for compound 4 lay 1.2-fold (0.09 log units) above the measured number, within the range that was stated.
By their numbers in this assay, from the lowest: compounds 2, 4 and 1 (each within the scatter of the next, the first and the last beyond it). At a limit, above all of these: compound 3.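

In this assay, iodo in place of ethynyl on this aromatic carbon stays within the scatter, a 2.0-fold lower number from compound 1 to compound 4 (0.29 log units; within the scatter), and 3-iodophenyl is not separated from the 3-bromo-4-fluorophenyl group, a 1.2-fold higher number from compound 2 to compound 4 (0.09 log units; within the scatter). Iodo in place of methoxy, however, gives an at least 3.4-fold lower number from compound 3 to compound 4 (0.53 log units; beyond the scatter). That step rests on a limit for compound 3: the limit of > 50000 nM in this assay, at which 1 of the 4 values shown sits. From the compounds shown here alone, whether chloro, a nitrile or an amine on this carbon would stay within the scatter of compound 4 remains open.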